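A Hydroxymethylphenyl Replaces Methoxyphenyl on the Ring Nitrogen

The compounds below may be only part of what the source reports. "The series", "measured", "known", "first", "only" and "open" are said of these compounds alone.

Compound 1 `COc1ccccc1-n1cc(COc2c(/C=C\C(=O)O)ccc(OC)c2CC=C(C)C)nn1` in a functional assay on HCT-116 cells (Homo sapiens) for cytotoxicity, read by MTT assay, with a stated time of 24 h (on this read-out lower numbers stand for stronger inhibition and higher numbers for weaker inhibition), gives 32200 nM. Among the measured compounds shown here, its only measured neighbour, compound 2 `COc1cccc(-n2cc(COc3c(/C=C\C(=O)O)ccc(OC)c3CC=C(C)C)nn2)c1`, gives 21600 nM in this assay, and the two numbers lie within the usual scatter of each other. Compound 3 `COc1ccc(/C=C\C(=O)O)c(OCc2cn(-c3ccc(CO)cc3)nn2)c1CC=C(C)C` differs from compound 1 by 4-(hydroxymethyl)phenyl in place of 2-methoxyphenyl on an aromatic nitrogen. For the measured compounds named here, the one measured step that bears on this change, a 1.5-fold lower number from compound 1 to compound 2 (0.17 log units; within the scatter), also swapped the group on that nitrogen and stayed within the scatter. A step of similar size, or none beyond the scatter, is therefore expected, a 1.3-fold lower number from compound 1 to compound 3 (0.11 log units; within the scatter). Compound 3 is estimated at 25000 nM, within a range of 10000 nM to 60000 nM.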

Compound 3, half-maximal inhibitory concentration: 31700 nM
For compound 3 the middle estimate is 1.3-fold (0.10 log units) below the measured one; measured number inside the range.
By their numbers in this assay, from the lowest: compounds 2, 3 and 1 (each within the scatter of the next).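

In this assay, 4-(hydroxymethyl)phenyl on the aromatic nitrogen reads the same within the scatter as 2-methoxyphenyl (a 1.0-fold lower number from compound 1 to compound 3 (0.01 log units; within the scatter)) and as 3-methoxyphenyl (a 1.5-fold higher number from compound 2 to compound 3 (0.17 log units; within the scatter)). Across compounds 1, 2 and 3, then, this position tolerates a hydrogen-bond donor in the entering group without a change beyond the scatter. No measurement available here accounts for this result. Still open, on these data alone, is whether an amine or a carboxylic acid on that phenyl ring, or a longer chain in its place, would shift the number beyond the scatter.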